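Cytotoxicity notes: indolyl, chlorophenyl and nitrophenyl biaryl acids

This account rests on a few compounds, and the source may have more. Where it says the series, first, only, none or still open, it means among the compounds named here.

Measured compounds:
- Compound 1 `CC(C)N(Cc1cccc(OCCCCCC(=O)O)c1)C(=O)c1ccc(-c2ccc3cc[nH]c3c2)cc1`: in an ADME assay on Raji cells (Homo sapiens) for cytotoxicity, read by CellTiter-Glo and resazurin assay, with a stated time of 72 h (on this read-out lower numbers stand for an effect already at smaller amounts and higher numbers for an effect only at larger amounts of compound), compound 1 gives > 26000 nM, which is a limit of the assay and not a number.
- Compound 2 `CC(C)N(Cc1cccc(OCCCCCC(=O)O)c1)C(=O)c1ccc(-c2cccc(Cl)c2)cc1`: in this assay compound 2 gives > 21900 nM, again a limit of the assay rather than a number.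

Among the compounds with values here, compound 2 therefore stands at a limit, and the only other value shown is also a limit (the limit of > 21900 nM in this assay, at which 1 of the 2 values shown sits, and (the limit of > 26000 nM in this assay, at which 1 of the 2 values shown sits)). Within the data shown here, the single measured step, a step that the two limits leave unreadable from compound 1 to compound 2, is unreadable because both ends are limits.

The step now followed goes from compound 2 to compound 3 `CC(C)N(Cc1cccc(OCCCCCC(=O)O)c1)C(=O)c1ccc(-c2cccc([N+](=O)[O-])c2)cc1`: nitro in place of chloro on an aromatic carbon. Among the measured compounds shown here, no measured step covers this change, and the one step that exists gives no readable size, so there is no basis for expecting a shift in this assay in either direction beyond the scatter. The expectation for compound 3 is accordingly that it behaves like compound 2, i.e. an estimated step that the limit leaves unreadable from compound 2 to compound 3, most likely ending once more at a limit. Compound 3 is estimated at 30000 nM, with a range from 10000 nM to 100000 nM.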

Compound 3, half-maximal effective concentration: > 26000 nM
Compound 3 ended at the assay's limit; the forecaster's own chance of this, stated with the estimate: 80%; the middle value does not contradict the limit.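

Compound 3 gives > 26000 nM in this assay, a limit of the assay and not a number. Within the data shown here, compound 1 and compound 2 also stand at limits, so no step among the three compounds can be read. The compounds shown leave open whether the 1H-indol-6-yl, 3-chlorophenyl and 3-nitrophenyl compounds differ at all in this assay.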